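Naphthyloxyacetyl hydrazones: cytotoxicity on HEL cells

The source may report more compounds than this note shows. Statements on the series, on what has been measured and on what is new or still open speak of the compounds shown alone.

Measured so far:
compound 1, `O=C(COc1cccc2ccccc12)N/N=C/c1ccc(Cl)cc1`: 100 ug/mL
compound 2, `C/C(=N\NC(=O)COc1cccc2ccccc12)c1ccccc1O`: 4 ug/mL

In an ADME assay on HEL cells (Homo sapiens) for cytotoxicity (on this read-out lower numbers stand for higher toxicity in this test and higher numbers for lower toxicity in this test), compound 2 gives the lowest of the two numbers; compound 1 sits higher by a margin well beyond the scatter, so compound 2 is the more toxic of the pair.

Compound 3, `C/C(=N\NC(=O)COc1cccc2ccccc12)c1ccccc1Br`, carries bromo in place of hydroxy on an aromatic carbon; the hydroxy leaves and bromo enters at an aromatic carbon of a six-membered aromatic ring of carbon only, ortho to a large group.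

Among the compounds with values here, with no step of this kind measured, the expected step of a 5.0-fold higher number from compound 2 to compound 3 (0.70 log units; beyond the scatter) is a moderate rise toward lower toxicity. The estimate for compound 3 in this assay is 20 ug/mL, between 5 ug/mL and 80 ug/mL.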

Compound 3, half-maximal cytotoxic concentration: 16.2 ug/mL
Compound 3: middle estimate off by 1.2-fold (0.09 log units), on the high side; measured number inside the range.
By their numbers in this assay, from the lowest: compound 2; then compound 3; then compound 1.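

In this assay, within the data shown here, the change from 2-hydroxyphenyl to 2-bromophenyl gives a 4.1-fold higher number from compound 2 to compound 3 (0.61 log units; beyond the scatter) and is the first step that isolates a single place, an aromatic carbon ortho to a large group. Replacing hydroxy with bromo at this position is therefore enough on its own to move the read-out toward lower toxicity in this test. No available evidence bears on the reason for this step.

From the compounds shown here alone, it remains open whether a methoxy group or an amine at this position would give a number closer to compound 2 or to compound 3. Going by these compounds, the effect of the same change at other positions on the ring also remains open.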